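Adding one methyl to compound 2

The source may report more compounds than this note shows. Statements on the series, on what has been measured and on what is new or still open speak of the compounds shown alone.

Measured in a functional assay on cells (Melanoma tumor cell line, Homo sapiens) for inhibition; on this read-out lower numbers stand for stronger inhibition of growth and higher numbers for weaker inhibition of growth:
Compound 1 `Cc1ccnc2nc(-c3cccc(Cl)c3)cc(O)c12`: 70800 nM
Compound 2 `Cc1ccc2c(O)cc(-c3cccc(Cl)c3)nc2n1`: 69200 nM

Only these two numbers exist so far, and they lie within the usual scatter of each other, so compound 2 cannot be told apart from compound 1. Compound 3 `Cc1cc(C)c2c(O)cc(-c3cccc(Cl)c3)nc2n1` differs from compound 2 in one place: methyl in place of hydrogen on an aromatic carbon. This is a methyl in place of hydrogen on an aromatic carbon, opposite the ring nitrogen. Among the measured compounds shown here, no measured pair of compounds shows what such a swap does, so the forecast has little to rest on. For the measured compounds named here, the close match of compound 1 at 70800 nM and compound 2 at 69200 nM offers the only guide. In this assay the expected step of a 1.2-fold lower number from compound 2 to compound 3 (0.06 log units; within the scatter) stays within the scatter, with no firm direction. For compound 3 the estimated value is 60000 nM, with an expected range of 25000 nM to 100000 nM.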

Compound 3, concentration for total growth inhibition: 72400 nM
Beside the measured number, compound 3's estimate is 1.2-fold (0.08 log units) below it; the range from low to high includes it.
By their numbers in this assay, from the lowest: compounds 2, 1 and 3 (each within the scatter of the next).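

In this assay, a methyl on the aromatic carbon opposite the ring nitrogen gives a 1.0-fold higher number from compound 2 to compound 3 (0.02 log units; within the scatter) and so cannot be told apart from the hydrogen it replaces. At this position the core therefore accepts one added carbon with no detectable loss or gain in growth inhibition, at least at this weak level of the read-out. The listed comparison with the other single-methyl compound gives a 1.0-fold higher number from compound 1 to compound 3 (0.01 log units; within the scatter) and likewise shows no separation, so all three compounds remain indistinguishable. No independent measurement here speaks to the reason for this result.

On these data alone, whether an amine, a carboxylic acid or a longer chain at this position would move the number remains open. So does the question of whether the methyl would still make no difference on a version of the core that inhibits growth more strongly.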